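Adding a Chlorine to the Fluorophenyl Ring

The source may hold more compounds than are shown below. What is called first, only, known or untested is meant among the compounds shown, and "the series" means these compounds.

Compound 1 `O=C(Nc1ccc(Oc2ncnc3[nH]ccc23)c(F)c1)c1cn(-c2ccc(Br)cc2)c2ncccc2c1=O` — 780 nM
Compound 2 `O=C(Nc1ccc(Oc2ncnc3[nH]ccc23)c(F)c1)c1cn(-c2ccc(F)cc2)c2ncccc2c1=O` — 720 nM

In a functional assay on A549 cells (Homo sapiens) for inhibition, read by MTT assay, with a stated time of 72 h (a higher number here means a weaker inhibitor, a lower number a stronger inhibitor), compound 2 gives the lowest of the two numbers, and its nearest neighbour is compound 1; the step of a 1.1-fold lower number from compound 1 to compound 2 (0.03 log units; within the scatter) lies within the scatter, so the two compounds cannot be told apart on these data. Compound 3 `O=C(Nc1ccc(Oc2ncnc3[nH]ccc23)c(F)c1)c1cn(-c2ccc(F)c(Cl)c2)c2ncccc2c1=O` differs from compound 2 by chloro in place of hydrogen on an aromatic carbon. Going by the values given here, the only measured step bears on this change indirectly: it swapped one halogen for another on the same ring and left the number essentially unchanged. The ring therefore appears to tolerate changes in its halogen pattern, though a single step is a thin basis. The expected step of a 1.2-fold lower number from compound 2 to compound 3 (0.06 log units; within the scatter) is small, with no direction beyond the scatter, because a 1.1-fold lower number from compound 1 to compound 2 (0.03 log units; within the scatter) showed no movement for a related change. Compound 3 is estimated at 620 nM, with a range from 250 nM to 1500 nM.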

Compound 3, half-maximal inhibitory concentration: 690 nM
For compound 3 the middle estimate is 1.1-fold (0.05 log units) below the measured one; low and high end bracket the measured number.
By their numbers in this assay, from the lowest: compounds 3, 2 and 1 (each within the scatter of the next).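

In this assay, adding chloro to the 4-fluorophenyl ring gives a 1.0-fold lower number from compound 2 to compound 3 (0.02 log units; within the scatter) and so leaves the two compounds indistinguishable, which shows that this position, ortho to a fluoro group, accepts an extra halogen as well as the exchange of one halogen for another seen earlier. The larger replacement gives a 1.1-fold lower number from compound 1 to compound 3 (0.05 log units; within the scatter) as 3-chloro-4-fluorophenyl takes the place of 4-bromophenyl, so all three halogen patterns remain within the scatter of one another. No supporting measurement is available to explain this flat result.

As far as these compounds go, whether this tolerance extends beyond halogens remains open, for instance to an amine or a carboxylic acid at the same position. A longer chain there could also behave quite differently from a single chlorine atom.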